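The source may hold more compounds than are shown below. What is called first, only, known or untested is meant among the compounds shown, and "the series" means these compounds.

Measured compounds:
- compound 1, `COC(=O)c1c(F)cccc1OC(=O)COc1cc(O)c2c(=O)cc(-c3ccccc3)oc2c1`: 319000 nM
- compound 2, `COC(=O)c1cccc(Cl)c1OC(=O)COc1cc(O)c2c(=O)cc(-c3ccccc3)oc2c1`: 366000 nM
- compound 3, `COC(=O)c1cc(C)ccc1OC(=O)COc1cc(O)c2c(=O)cc(-c3ccccc3)oc2c1`: 306000 nM

In an ADME assay on cells (T-cell, Mus musculus, strain BALB/c) for cytotoxicity, read by MTT assay, with a stated time of 48 h (on this read-out higher numbers stand for lower toxicity in this test and lower numbers for higher toxicity in this test), the three measured compounds sit close together. Compound 3 stands within the scatter of both others: the step of a 1.0-fold lower number from compound 1 to compound 3 (0.02 log units; within the scatter) and the step of a 1.2-fold lower number from compound 2 to compound 3 (0.08 log units; within the scatter) are each within the scatter, as is the step of a 1.1-fold higher number from compound 1 to compound 2 (0.06 log units; within the scatter) between the other two. Nothing among these numbers separates one compound from another.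

Compound 4 has the structure `COC(=O)c1ccc(Br)cc1OC(=O)COc1cc(O)c2c(=O)cc(-c3ccccc3)oc2c1` and has not yet been measured in this assay. Compared with compound 3, (a group of 11 heavy atoms (8 carbon, 2 oxygen, 1 bromine; one six-membered aromatic ring of carbon only) in place of a group of 11 heavy atoms (9 carbon, 2 oxygen; one six-membered aromatic ring of carbon only), on an oxygen next to a carbonyl group). Going by the values given here, three measured steps bear on this change, since each exchanges one such group for another on the same oxygen, and all three are within the scatter. The bromine-bearing group entering here is not itself among the measured substituents, but the closest analogues, the fluorine- and chlorine-bearing groups of compound 1 and compound 2, give the same read as the methyl-bearing group of compound 3.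

Compound 4 is therefore expected to show no step beyond the scatter, a 1.1-fold higher number from compound 3 to compound 4 (0.03 log units; within the scatter). The half-maximal cytotoxic concentration of compound 4 in this assay is estimated at 330000 nM, within a range of 200000 nM to 550000 nM.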

Compound 4, half-maximal cytotoxic concentration: 326000 nM
Estimate against measurement, compound 4: 1.0-fold (0.01 log units) above; measured number inside the range.
By their numbers in this assay, from the lowest: compounds 3, 1, 4 and 2 (each within the scatter of the next).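

Read in this assay the bromine-bearing group on an oxygen next to a carbonyl group does not separate from any of the three groups already measured at this place: the step of a 1.1-fold higher number from compound 3 to compound 4 (0.03 log units; within the scatter) and the step of a 1.1-fold lower number from compound 2 to compound 4 (0.05 log units; within the scatter) and the step of a 1.0-fold higher number from compound 1 to compound 4 (0.01 log units; within the scatter) all lie within the scatter. Going by these compounds alone, the flat read seen with the fluorine-bearing, chlorine-bearing and methyl-bearing groups therefore now extends to a third halogen, and no compound among the four goes against it. Nothing measured here gives a reason for this sameness.

What the compounds shown leave open is whether the read stays flat when the group on this oxygen is of another kind, such as one carrying an amine or a carboxylic acid, or a longer chain in place of the methoxycarbonyl group. They also leave open whether changes elsewhere on the shared core would move the half-maximal cytotoxic concentration at all, since all four compounds differ only in this one group.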